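This account rests on a few compounds, and the source may have more. Where it says the series, first, only, none or still open, it means among the compounds named here.

Among the compounds with values here, compound 2 `CCOc1cc(OC)ccc1C(C)=O` gives 37700000 nM in a functional assay, read by spectrophotometry, with a stated time of 6 min (on this read-out higher numbers stand for weaker inhibition and lower numbers for stronger inhibition), the higher of the two numbers recorded, though its only neighbour, compound 1 `CCOc1cc(OC)c(Br)cc1C(C)=O` with 36000000 nM, lies within the scatter: a 1.0-fold higher number from compound 1 to compound 2 (0.02 log units; within the scatter). Compound 3 `CCCCCCCCOc1cc(OC)ccc1C(C)=O` is not yet measured; it differs from compound 2 by hexyl in place of hydrogen on a saturated chain carbon, two bonds along the chain from an oxygen on an aromatic ring. Within the data shown here, no measured step touches the chain at this position, and the only step available, from bromo to hydrogen on the ring, does not bear on this change. With nothing to rest on, no step beyond the scatter is expected from compound 2 to compound 3 in this assay: a 1.1-fold lower number from compound 2 to compound 3 (0.03 log units; within the scatter). Compound 3 is therefore estimated at 35000000 nM, between 8000000 nM and 150000000 nM.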

Compound 3, half-maximal inhibitory concentration: 38300000 nM
Compound 3: middle estimate off by 1.1-fold (0.04 log units), on the low side; low and high end bracket the measured number.
By their numbers in this assay, from the lowest: compounds 1, 2 and 3 (each within the scatter of the next).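

In this assay, hexyl in place of hydrogen on this saturated chain carbon gives a 1.0-fold higher number from compound 2 to compound 3 (0.01 log units; within the scatter) and so stays within the scatter. Within the data shown here, this is the first measured change on the chain, and it shows that adding these six carbons leaves the read-out without a step beyond the scatter. Nothing at hand explains this result.

The compounds shown leave open whether an amine or a carboxylic acid at this position, or a longer chain, would give a step beyond the scatter. They also leave open whether hexyl gives the same result alongside bromo.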